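The source may hold more compounds than are shown below. What is called first, only, known or untested is meant among the compounds shown, and "the series" means these compounds.

For the measured compounds named here, in a functional assay on A2780 cells (Homo sapiens) for inhibition, read by sulforhodamine B assay, with a stated time of 96 h (on this read-out higher numbers stand for weaker inhibition of growth and lower numbers for stronger inhibition of growth), compound 1 `CCC(O)[C@@H](CC)Nc1nc(NCc2ccccn2)c2ncn(C(C)C)c2n1` gives 22000 nM and compound 2 `CC[C@H](Nc1nc(NCc2ccccn2)c2ncn(C(C)C)c2n1)C(C)O` gives 10000 nM, so compound 2 holds the lower of the two numbers so far. Compound 3 `CCC(O)[C@H](CC)Nc1nc(NCc2ccccn2)c2ncn(C(C)C)c2n1` follows from compound 2 by methyl in place of hydrogen on a saturated chain carbon, two bonds along the chain from an oxygen on a saturated carbon, turning 1-(1-hydroxyethyl)propyl into 1-ethyl-2-hydroxybutyl. Going by the values given here, only one measured step bears on this: a 2.2-fold lower number from compound 1 to compound 2 (0.34 log units; beyond the scatter), modest but beyond the scatter. It runs the opposite way, from 1-ethyl-2-hydroxybutyl to 1-(1-hydroxyethyl)propyl. Compound 1 and compound 3 are not the same structure, so the reversed step is only a guide, and a single step sets no trend. A modest rise in the number is therefore expected in this assay, with a result inside the scatter still possible. The expected step is a 1.5-fold higher number from compound 2 to compound 3 (0.18 log units; within the scatter). The estimate for compound 3 is 15000 nM, with an expected range of 7000 nM to 32000 nM.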

Compound 3, concentration for 50% growth inhibition: 21000 nM
Beside the measured number, compound 3's estimate is 1.4-fold (0.15 log units) below it; measured number inside the range.
By their numbers in this assay, from the lowest: compound 2; then compounds 3 and 1 (each within the scatter of the next).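

In this assay, extending 1-hydroxyethyl to 1-hydroxypropyl at this saturated chain carbon gives a 2.1-fold higher number from compound 2 to compound 3 (0.32 log units; beyond the scatter), a modest step in the direction of weaker inhibition of growth. This places compound 2 apart from both 1-ethyl-2-hydroxybutyl compounds, while the change in drawn stereochemistry leaves no readable difference in the number: a 1.0-fold lower number from compound 1 to compound 3 (0.02 log units; within the scatter). That pair cannot be taken as a clean comparison of two fully defined configurations because of how the two structures are drawn: the fact that one of compounds 1 and 3 is drawn with a defined configuration and the other without, at the place where they differ

The compounds shown leave open whether a longer chain such as 1-hydroxybutyl, or an amine or a carboxylic acid in place of the hydroxyl, would move the number further from that of compound 2, 10000 nM. With three compounds, no trend along the chain can be claimed, and the separate contribution of each stereo element remains unresolved.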